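The compounds below may be only part of what the source reports. "The series", "measured", "known", "first", "only" and "open" are said of these compounds alone.

Within the data shown here, compound 2 `CN(C)C1(Cc2ccccc2)CCN(c2cc(C(F)(F)F)ccc2CNC(=O)Nc2cccc3c2CC(O)CC3)CC1` gives the lowest of the two numbers so far: in an assay on CHO cells for antagonist activity at transient receptor potential cation channel subfamily V member 1 (Homo sapiens), read by scintillation counting, with a stated time of 5 min, in the presence of a further agent that is not named here (a higher number here means that more compound is needed for the effect, a lower number that less compound is needed), compound 2 gives 10.1 nM, whereas compound 1 `CN(C)C1(Cc2ccccc2)CCN(c2cc(C(F)(F)F)ccc2CNC(=O)NCc2ccc(NS(C)(=O)=O)c(F)c2)CC1` in this assay gives 85.9 nM, a gap beyond the scatter. Compound 3 `CN(C)C1(Cc2ccccc2)CCN(c2cc(C(F)(F)F)ccc2CNC(=O)Nc2ccc3cccnc3c2)CC1` differs from compound 2 only at the urea end: quinolin-7-yl in place of 3-hydroxy-1,2,3,4-tetrahydronaphthalen-5-yl on an amide-type nitrogen. Among the measured compounds shown here, no measured pair shows this change, so the size of the step is uncertain. A modest loss is expected, and compound 3 in this assay is estimated at 25 nM (range 8 nM to 80 nM), which means an expected step of a 2.5-fold higher number from compound 2 to compound 3 (0.39 log units; beyond the scatter).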

Compound 3, half-maximal effective concentration: 42 nM
The estimate for compound 3 lay 1.7-fold (0.23 log units) below the measured number; the measured number falls inside the stated range.
By their numbers in this assay, from the lowest: compound 2; then compound 3; then compound 1.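

In this assay, quinolin-7-yl in place of 3-hydroxy-1,2,3,4-tetrahydronaphthalen-5-yl on an amide-type nitrogen gives a 4.2-fold higher number from compound 2 to compound 3 (0.62 log units; beyond the scatter). Among these compounds, this is the first single-place reading at the urea end: the position responds to the change, but the step is modest and compound 3 keeps a measurable value. The data on hand give no reason for this step. From the compounds shown here alone, the change removes the hydroxy group and adds a ring nitrogen together, so their separate shares stay open. An amine or a methoxy group in place of that hydroxy group remains an open case.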